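The source may report more compounds than this note shows. Statements on the series, on what has been measured and on what is new or still open speak of the compounds shown alone.

Of the compounds shown here, three built on one shared core have been measured. Compound 1 `COc1ccc(-c2cc(/C=C/C(=O)c3ccc(N)cc3)[nH]n2)cc1`, compound 2 `COc1cc(-c2cc(/C=C/C(=O)c3ccc(N)cc3)[nH]n2)cc(OC)c1OC` and compound 3 `COc1cc(-c2cc(/C=C/C(=O)c3ccc(F)c(F)c3)[nH]n2)cc(OC)c1OC` were tested in a functional assay on 786-0 cells (Homo sapiens) for cytotoxicity, read by sulforhodamine B assay, with a stated time of 48 h, tested at 100 uM; a lower number here means a stronger effect, a higher number a weaker effect of the compound at the concentration tested. In this assay compound 1 gives -57%, compound 2 gives -90% and compound 3 gives -47%. Compound 2 thus has the lowest number of the three: compound 1 stands above it beyond the scatter, and compound 3 stands further above it. Among the compounds with values here, the one step between compounds that differ in a single place is a number 43 percentage points higher from compound 2 to compound 3 (beyond the scatter), which concerns the group on the carbonyl carbon and not the methoxy groups.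

Compound 4 `COc1ccc(-c2cc(/C=C/C(=O)c3ccc(N)cc3)[nH]n2)cc1OC` has not yet been measured. It differs from compound 2 in one place: hydrogen in place of methoxy on an aromatic carbon. Within the data shown here, no measured pair differs in exactly this way, so no single step speaks to it directly. Among the measured compounds shown here, the only guidance comes from compound 1 and compound 2, which differ in how many methoxy groups they carry and whose numbers lie apart beyond the scatter. Compound 4 sits between them in this respect, so its number is expected to fall between theirs. The step of a number 15 percentage points higher from compound 2 to compound 4 (beyond the scatter) is therefore expected to be a moderate rise. For compound 4 the estimate in this assay is -75%, with a range from -95% to -50%.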

Compound 4, a percentage reported as activity, at one concentration (the size of the read-out at that concentration, not a potency): -97%
The estimate for compound 4 lay 22 percentage points above the measured number, outside the stated range (below it).
By their numbers in this assay, from the lowest: compounds 4 and 2 (each within the scatter of the next); then compounds 1 and 3 (each within the scatter of the next).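

In this assay, putting hydrogen in place of methoxy on the aromatic carbon that is ortho to a methoxy group and meta to a large group gives a number 7 percentage points lower from compound 2 to compound 4 (within the scatter), so this read-out does not separate the two groups at this position. A different methoxy group does count: methoxy in place of hydrogen on an aromatic carbon gives a number 40 percentage points lower from compound 1 to compound 4 (beyond the scatter), which is a large step, so within these compounds the outcome of changing between methoxy and hydrogen depends on which aromatic carbon is changed. Nothing available explains this difference between the two aromatic carbons.

The compounds shown leave open whether this position accepts groups other than hydrogen and methoxy with the same result, such as a hydroxyl group, a chlorine atom or the longer ethoxy chain. They also leave open whether hydrogen and methoxy remain indistinguishable here when 3,4-difluorophenyl takes the place of 4-aminophenyl on the carbonyl carbon, the change that separated compound 2 from compound 3 in this assay.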